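The compounds below may be only part of what the source reports. "The series", "measured", "known", "first", "only" and "open" are said of these compounds alone.

Measured so far:

- Compound 1 `COC(=O)c1ccc(NC(=O)c2cc3ccccc3s2)cc1`: 20 ug/mL
- Compound 2 `COC(=O)c1ccc(NC(=O)c2cc3cc([N+](=O)[O-])ccc3s2)cc1`: 10 ug/mL

In a physicochemical assay for solubility (on this read-out lower numbers stand for lower solubility and higher numbers for higher solubility), compound 1 gives 20 ug/mL, the higher of the two numbers, while compound 2 gives 10 ug/mL. Within the data shown here, the only step between measured compounds, a 2.0-fold lower number from compound 1 to compound 2 (0.30 log units; within the scatter), puts nitro in place of hydrogen on an aromatic carbon.

Compound 3 `NC(=O)c1ccc(NC(=O)c2cc3ccccc3s2)cc1` is not yet measured. It differs from compound 1 by amino in place of methoxy on a carbonyl carbon; one bond further out, methoxycarbonyl becomes carbamoyl. Among the measured compounds shown here, no measured step touches this part of the shared core, so the nitro step offers no guidance here and the expectation rests on the change itself, with wide uncertainty.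

Compound 3 is expected at 35 ug/mL, within 10 ug/mL to 120 ug/mL; this estimate means a 1.8-fold higher number from compound 1 to compound 3 (0.24 log units; within the scatter), a rise that may still fall inside the scatter.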

Compound 3, solubility: 25 ug/mL
Estimate against measurement, compound 3: 1.4-fold (0.15 log units) above; the measured number falls inside the stated range.
By their numbers in this assay, from the lowest: compounds 2, 1 and 3 (each within the scatter of the next, the first and the last beyond it).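

In this assay, among these compounds, the first change at this carbonyl carbon, amino in place of methoxy, leaves the two compounds indistinguishable (a 1.3-fold higher number from compound 1 to compound 3 (0.10 log units; within the scatter)). The methoxycarbonyl of compound 1 can therefore become the carbamoyl of compound 3, with a hydrogen-bond donor entering and a hydrogen-bond acceptor leaving, without a difference in this read-out that stands clear of the usual scatter of repeated measurements. No supporting measurement here accounts for this result.

Still open, going by these compounds, is whether any group on this carbonyl carbon can move the number beyond the scatter, for example the hydroxyl of a carboxylic acid, a dimethylamino group or the longer chain of an ethyl ester. A single step also cannot show whether other replacements at this carbon would behave in the same way.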